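The source may hold more compounds than are shown below. What is called first, only, known or untested is meant among the compounds shown, and "the series" means these compounds.

In a functional assay on HeLa cells (Homo sapiens) for inhibition, read by CCK-8 assay, with a stated time of 48 h (on this read-out lower numbers stand for stronger inhibition and higher numbers for weaker inhibition), compound 1 (`Cc1cc(C)cc(NC(=O)NCCNS(=O)(=O)c2ccc(-c3ccccc3Oc3ccc([N+](=O)[O-])c([N+](=O)[O-])c3)s2)c1`) gives 12000 nM. Compound 2 (`O=C(NCCNS(=O)(=O)c1ccc(-c2ccccc2OCc2cccc(O)c2)s1)Nc1cc(C(F)(F)F)cc(C(F)(F)F)c1`) gives 17300 nM, and the two values lie within the scatter of each other. For compound 3 (`Cc1cc(C)cc(NC(=O)NCCNS(=O)(=O)c2ccc(-c3ccccc3OCc3ccccc3)s2)c1`) the assay reports only a limit, > 50000 nM.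

Compound 4 (`COc1cccc(NC(=O)NCCNS(=O)(=O)c2ccc(-c3ccccc3Oc3ccc([N+](=O)[O-])c([N+](=O)[O-])c3)s2)c1`) has 3-methoxyphenyl in place of 3,5-dimethylphenyl on an amide-type nitrogen, (3-methoxyphenyl in place of 3,5-dimethylphenyl on an amide-type nitrogen). The rest of compound 1 is kept, including the 3,4-dinitrophenyl group.

Only one measured step links two of these compounds in a single place: an at least 4.1-fold higher number from compound 1 to compound 3 (0.61 log units; beyond the scatter). It puts benzyl in place of 3,4-dinitrophenyl on an oxygen on an aromatic ring, and it leaves the group on the amide-type nitrogen untouched. It therefore gives no size for the present change. It bears on compound 4 only in that compound 4 retains the group whose loss in compound 3 came with that rise. Within the data shown here, no measured step varies the amide-type nitrogen substituent alone, so no shift beyond the scatter is expected. The expected step, a 1.3-fold higher number from compound 1 to compound 4 (0.10 log units; within the scatter), is an estimate that rests on this lack of evidence for a shift.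

For compound 4 the expected value is 15000 nM, with an estimated range of 6000 nM to 40000 nM.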

Compound 4, half-maximal inhibitory concentration: > 20000 nM
Compound 4 was reported as a limit; the forecaster's own chance of this, stated with the estimate: 15%; at least 1.3-fold (0.12 log units) between middle value and limit.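

Among these compounds, the first measured change on the amide-type nitrogen, made with the 3,4-dinitrophenyl group kept, is an at least 1.6-fold higher number from compound 1 to compound 4 (0.22 log units; that floor lies within the scatter). This step has only a floor, so its true size may lie within the scatter or well beyond it, and the 3,5-dimethylphenyl and 3-methoxyphenyl groups cannot yet be ranked at this position. Compound 4 is reported only as a limit in this assay, and this leaves the step without an upper end: the limit of > 20000 nM in this assay, at which 1 of the 4 values shown sits.

The compounds shown leave open how large the change from 3,5-dimethylphenyl to 3-methoxyphenyl really is, and whether a measured value for a close relative could settle it, such as one carrying a plain phenyl or a 3-hydroxyphenyl group on the amide-type nitrogen. They also leave open how a pyridine ring, or a phenyl ring bearing a carboxylic acid or an amine, would read on this nitrogen with the rest of compound 1 kept.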